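Branched to straight chain on the amide of compound 1

This account rests on a few compounds, and the source may have more. Where it says the series, first, only, none or still open, it means among the compounds named here.

Of the compounds shown here, three built on one shared core have been measured in a functional assay on B16 cells (Mus musculus) for inhibition; on this read-out higher numbers stand for weaker inhibition and lower numbers for stronger inhibition. Compound 1 `COc1cc(/C=C/C(=O)c2cccc(NC(=O)C(C)C)c2)ccc1O` carries an isopropyl group on the carbonyl carbon of its amide, and in this assay compound 1 gives 1.09 ug/mL, the lowest number of the three. Compound 2 `COC(=O)C(=O)Nc1cccc(C(=O)/C=C/c2ccc(O)c(OC)c2)c1` gives 4.41 ug/mL, and compound 3 `COc1cc(/C=C/C(=O)c2cccc(NC(=O)c3cccs3)c2)ccc1O` gives 6.93 ug/mL. The steps from compound 1 are a 4.0-fold higher number from compound 1 to compound 2 (0.61 log units; beyond the scatter) and a 6.4-fold higher number from compound 1 to compound 3 (0.80 log units; beyond the scatter), both beyond the scatter; between compound 2 and compound 3 the step is a 1.6-fold higher number from compound 2 to compound 3 (0.20 log units; within the scatter), within the scatter.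

Compound 4 `CCCC(=O)Nc1cccc(C(=O)/C=C/c2ccc(O)c(OC)c2)c1` has not yet been measured. It differs from compound 1 by propyl in place of isopropyl on a carbonyl carbon. Both measured steps from compound 1 replaced the isopropyl group with something quite different, a methoxycarbonyl or a thiophen-2-yl, and each gave a modest weakening. The change to propyl keeps the same atoms and only straightens the chain, so neither of those steps speaks directly for it, and no step beyond the scatter is expected, perhaps a slight drift toward a higher number. The step from compound 1 to compound 4 is thus estimated as a 1.3-fold higher number from compound 1 to compound 4 (0.11 log units; within the scatter). Compound 4 is expected to give about 1.4 ug/mL, between 0.6 ug/mL and 3.5 ug/mL.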

Compound 4, half-maximal inhibitory concentration: 1.43 ug/mL
Compound 4: the middle estimate sits 1.0-fold (0.01 log units) below what was measured, within the range that was stated.
By their numbers in this assay, from the lowest: compounds 1 and 4 (each within the scatter of the next); then compounds 2 and 3 (each within the scatter of the next).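

In this assay, moving from a branched to a straight chain on the carbonyl carbon of the amide gives a 1.3-fold higher number from compound 1 to compound 4 (0.12 log units; within the scatter) and so makes no difference that can be read, which means that the branch of the isopropyl group is not needed to keep the low number seen for compound 1. The propyl chain also stands clear of the other two groups, with a 4.8-fold lower number from compound 3 to compound 4 (0.69 log units; beyond the scatter) and a 3.1-fold lower number from compound 2 to compound 4 (0.49 log units; beyond the scatter) in the same assay, so the weaker numbers of compound 2 and compound 3 now contrast with two different chains rather than with the isopropyl group alone. Nothing measured here explains why the two chains give lower numbers than the thiophen-2-yl and methoxycarbonyl groups.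

How far this tolerance extends remains open, since the compounds shown do not reveal whether a smaller methyl group or a longer chain such as pentyl would stay in the same range. On these data alone, it is equally open whether a propyl chain ending in an amine or a carboxylic acid would keep the number low on this read-out.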